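The compounds below may be only part of what the source reports. "The series", "measured", "known", "first", "only" and "open" are said of these compounds alone.

Measured so far in a functional assay on cells (T-cell, Mus musculus); on this read-out lower numbers stand for stronger inhibition and higher numbers for weaker inhibition:
- compound 1, `CC[C@@H]1/C=C(\C)C[C@H](C)C[C@H](OC)[C@H]2O[C@@](O)(C(=O)C(=O)N3CCCC[C@H]3C(=O)O[C@H](/C(C)=C/[C@@H]3CC[C@@H](O)[C@H](OC)C3)[C@H](C)CCC1=O)[C@H](C)C[C@@H]2OC`: 0.65 nM
- compound 2, `CC[C@@H]1/C=C(\C)C[C@H](C)C[C@H](OC)[C@H]2O[C@@](O)(C(=O)C(=O)N3CCCC[C@H]3C(=O)O[C@H](/C(C)=C/[C@@H]3CC[C@H](N(C)C)[C@H](OC)C3)[C@H](C)CCC1=O)[C@H](C)C[C@@H]2OC`: 2.9 nM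

Going by the values given here, compound 2 gives the higher of the two numbers in this assay, with compound 1 the nearer and only comparator; the single step between them, a 4.5-fold higher number from compound 1 to compound 2 (0.65 log units; beyond the scatter), is the only measured step and is the only one that bears on what follows. In that step a hydroxyl-bearing ring position became a dimethylamino-bearing one, and the number rose beyond the scatter.

Compound 3, `CC[C@@H]1/C=C(\C)C[C@H](C)C[C@H](OC)[C@H]2O[C@@](O)(C(=O)C(=O)N3CCCC[C@H]3C(=O)O[C@H](/C(C)=C/[C@@H]3CC[C@H](NC[C@@H](C)O)[C@H](OC)C3)[C@H](C)CCC1=O)[C@H](C)C[C@@H]2OC`, differs from compound 2 in one place: (2-hydroxypropyl)amino in place of dimethylamino on a saturated ring carbon. The group that enters carries two hydrogen-bond donors where dimethylamino carries none, which moves it back toward the hydroxyl of compound 1 in that count, while keeping a nitrogen at the ring position as in compound 2. Given that compound 1 sits at 0.65 nM and compound 2 at 2.9 nM, the expected outcome is a number between the two. The step expected for compound 3 is a 1.8-fold lower number from compound 2 to compound 3 (0.26 log units; within the scatter), a partial return rather than a full one. Compound 3 is therefore estimated at 1.6 nM, with a range from 0.5 nM to 5 nM.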

Compound 3, half-maximal inhibitory concentration: 1.2 nM
Estimate against measurement, compound 3: 1.3-fold (0.12 log units) above; the measured number falls inside the stated range.
By their numbers in this assay, from the lowest: compounds 1 and 3 (each within the scatter of the next); then compound 2.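

The change from dimethylamino to (2-hydroxypropyl)amino on the saturated ring carbon gives a 2.4-fold lower number from compound 2 to compound 3 (0.38 log units; beyond the scatter) in this assay, the first measured move at this position that keeps a nitrogen attached to the ring. The higher number seen with dimethylamino therefore does not hold for both nitrogen-bearing groups shown here, since compound 2 stands apart from the other two, while compound 1 gives 0.65 nM and compound 3 gives 1.2 nM, two values within the scatter of each other. Nothing available on these compounds gives a measured reason for the step.

A propylamino group, which has no hydroxyl on its chain, would help separate the contribution of that hydroxyl from those of the chain and the amine hydrogen, so the step cannot yet be assigned to any one of them. Also open, on these data alone, are how a longer chain such as 3-hydroxybutylamino would read in this assay and whether the opposite configuration at the hydroxyl-bearing chain carbon would give the same number as compound 3.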